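Hydrogen for Methyl on an Aromatic Oxygen: Compound 4 Foreseen

The source may hold more compounds than are shown below. What is called first, only, known or untested is meant among the compounds shown, and "the series" means these compounds.

Compound 1 `COc1cc(-c2nn(-c3cccc(NC(=O)Nc4cc(C(F)(F)F)cc(C(F)(F)F)c4)c3)cc2-c2ccncc2)ccc1Cl`: 1540 nM
Compound 2 `COc1cc(-c2nn(-c3cccc(NC(=O)Nc4ccc(Cl)c(Cl)c4)c3)cc2-c2ccncc2)ccc1Cl`: 2270 nM
Compound 3 `O=C(Nc1cccc(-n2cc(-c3ccncc3)c(-c3ccc(Cl)c(O)c3)n2)c1)Nc1ccc(Cl)c(Cl)c1`: 4250 nM

In a functional assay on MDA-MB-468 cells (Homo sapiens) for inhibition, read by sulforhodamine B assay, with a stated time of 48 h (a higher number here means a weaker inhibitor of growth, a lower number a stronger inhibitor of growth), compound 1 gives 1540 nM, the lowest of the three numbers. Compound 2 gives 2270 nM, which lies within the scatter of compound 1; the difference between the two cores is not broken down here. Compound 3 differs from compound 2 by hydrogen in place of methyl on an oxygen on an aromatic ring, and that change made a step of a 1.9-fold higher number from compound 2 to compound 3 (0.27 log units; within the scatter). Compound 4 `O=C(Nc1cccc(-n2cc(-c3ccncc3)c(-c3ccc(Cl)c(O)c3)n2)c1)Nc1cc(C(F)(F)F)cc(C(F)(F)F)c1` has not yet been measured in this assay. It differs from compound 1 by hydrogen in place of methyl on an oxygen on an aromatic ring, at the same place, so this is the same change. Because the earlier step was a 1.9-fold higher number from compound 2 to compound 3 (0.27 log units; within the scatter), a step of about the same size is expected here, a 1.9-fold higher number from compound 1 to compound 4 (0.27 log units; within the scatter). For compound 4 the expected value in this assay is therefore 2900 nM, with a likely range from 1500 nM to 6000 nM.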

Compound 4, concentration for total growth inhibition: 2660 nM
Beside the measured number, compound 4's estimate is 1.1-fold (0.04 log units) above it, within the range that was stated.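

In this assay, the change from 4-chloro-3-methoxyphenyl to 4-chloro-3-hydroxyphenyl made a step of a 1.7-fold higher number from compound 1 to compound 4 (0.24 log units; within the scatter). Set beside the earlier step, the new one agrees with it: the same change on two cores in this assay, a 1.9-fold higher number (0.27 log units; within the scatter) from compound 2 to compound 3 and a 1.7-fold higher number (0.24 log units; within the scatter) from compound 1 to compound 4, 1.1-fold (0.04 log units) apart, within the scatter of two such steps The change therefore carried over between these two cores with a step of similar size, but each step lies within the scatter, so neither shows that the change really alters growth inhibition, and two cores do not establish a rule for the series.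

The compounds shown leave open what a longer chain on that oxygen, such as ethyl or propyl, would do, or an amine in place of the hydroxy group. Going by these compounds, whether the step holds on other cores also remains open.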